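Isopropyl for Methyl on the Chain Carbon

The source may hold more compounds than are shown below. What is called first, only, known or untested is meant among the compounds shown, and "the series" means these compounds.

Three compounds share one core and differ in a single region. Compound 1 `C[C@H](NC(=O)CN(c1nc(Cl)nc2[nH]cnc12)C1CC1)C(=O)OCc1ccccc1` gives 64.3% in a functional assay on the whole organism (Tail, strain ICR) with Mus musculus as the target, in the tail flick test, with a stated time of 60 min, at a dose of 25 umol/kg by the oral route (on this read-out lower numbers stand for a weaker effect and higher numbers for a stronger effect at the one dose given), the highest of the three numbers. Compound 3 `N=C(N)NCCC[C@H](NC(=O)CN(c1nc(Cl)nc2[nH]cnc12)C1CC1)C(=O)O` gives 51% in this assay, and compound 2 `O=C(O)[C@@H]1CCCN1C(=O)CN(c1nc(Cl)nc2[nH]cnc12)C1CC1` gives 34.9%; both fall below compound 1 by more than the scatter. Compound 4 `CC(C)[C@H](NC(=O)CN(c1nc(Cl)nc2[nH]cnc12)C1CC1)C(=O)OCc1ccccc1` has not yet been measured; it differs from compound 1 by isopropyl in place of methyl on a saturated chain carbon bound to an amide-type nitrogen and a carbonyl carbon. Going by the values given here, no pair of measured compounds isolates this change, so the expectation rests on compound 1 alone. The step of a number 4.3 percentage points lower from compound 1 to compound 4 (within the scatter) is expected to be small, most likely none beyond the scatter, in either direction. Compound 4 is therefore estimated at 60%, with a range from 45% to 75%.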

Compound 4, a percentage reported as activity, at one dose (the size of the read-out at that dose, not a potency): 55.5%
The estimate for compound 4 lay 4.5 percentage points above the measured number; measured number inside the range.
By their numbers in this assay, from the lowest: compound 2; then compounds 3, 4 and 1 (each within the scatter of the next, the first and the last beyond it).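

In this assay, isopropyl in place of methyl on this saturated chain carbon gives a number 8.8 percentage points lower from compound 1 to compound 4 (within the scatter), so the larger group is tolerated here without a step beyond the scatter. Going by these compounds alone, this is the only step read at this position, and it holds for this one pair alone. Nothing at hand explains the result. On these data alone, whether a longer chain, a phenyl ring or an amine on the same carbon would also stay within the scatter remains open.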